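The source may report more compounds than this note shows. Statements on the series, on what has been measured and on what is new or still open speak of the compounds shown alone.

Measured compounds:
Compound 1, `Cc1cc(O)cc(-c2nn(CC#N)cc2-c2ccnc(-c3ccc(Oc4ccccc4)cc3)c2)c1` — 94%
Compound 2, `COc1cc(C)cc(-c2nn(CC#N)cc2-c2ccnc(-c3ccc(N(C)C)cc3)c2)c1` — -22%

In a functional assay on SK-MEL-5 cells (Homo sapiens) for cytotoxicity, read by sulforhodamine B assay, with a stated time of 48 h, tested at 100 nM (a lower number here means a stronger effect, a higher number a weaker effect of the compound at the concentration tested), compound 1 gives 94%, while compound 2 gives -22%. Of the two numbers, compound 2 stands lowest; the nearest is compound 1, whose number lies higher by an amount beyond the scatter, so compound 2 shows the stronger effect of the pair. Going by the values given here, no single-point step between the two measured compounds is available, as compounds 1 and 2 differ in more than one place.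

Compound 3, `Cc1cc(O)cc(-c2nn(CC#N)cc2-c2ccnc(-c3ccc(N(C)C)cc3)c2)c1`, has not yet been measured. It differs from compound 2 in one place: hydrogen in place of methyl on an oxygen on an aromatic ring. Among the compounds with values here, compound 1 carries the same hydroxy group as compound 3 and gives the weaker reading, but it also differs elsewhere, so the two values show only that the pair spans a wide range.

The step from compound 2 to compound 3 is expected to be a rise of a number 37 percentage points higher from compound 2 to compound 3 (beyond the scatter), towards a weaker effect, though with considerable uncertainty. Compound 3 is therefore estimated at 15%, within a range from -20% to 70%.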

Compound 3, a percentage reported as activity, at one concentration (the size of the read-out at that concentration, not a potency): 82%
Estimate against measurement, compound 3: 67 percentage points below; the measured number lies above the stated range.
By their numbers in this assay, from the lowest: compound 2; then compound 3; then compound 1.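

In this assay, the change from methoxy to hydroxy on the aromatic ring, with everything else held, gives a number 104 percentage points higher from compound 2 to compound 3 (beyond the scatter), a large move towards a weaker effect, so this one methyl on the oxygen decides much of the reading at the concentration tested. With the hydroxy group kept, dimethylamino in place of phenoxy gives only a number 12 percentage points lower from compound 1 to compound 3 (beyond the scatter), a modest step, which shows that dimethylamino does not by itself bring back the strong effect of compound 2 and that, among these three compounds, the strong reading appears only with the methoxy group. Nothing available here explains why removing the methyl has so large an effect.

The compounds shown leave open whether the effect needs methoxy specifically or would survive a longer group on the same oxygen, such as ethoxy, or a replacement of the oxygen by an amine. Going by these compounds alone, they also leave open whether methoxy would give a similar gain with phenoxy in place of dimethylamino, as the methoxy step is seen only with dimethylamino present.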